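From Furan-2-yl to Phenyl at the Assay Limit

The source may hold more compounds than are shown below. What is called first, only, known or untested is meant among the compounds shown, and "the series" means these compounds.

Of the compounds shown here, two have been measured so far in an ADME assay on BJ cells (Homo sapiens), read by MTT assay, with a stated time of 72 h; a higher number here means a weaker inhibitor, a lower number a stronger inhibitor. Compound 1 (`Nc1nc(N)c2c(-c3cc4ccccc4o3)cn([C@@H]3O[C@H](CO)[C@@H](O)[C@H]3O)c2n1`) gives > 100000 nM, which is a limit of the assay and not a number. Compound 2 (`COc1nc(N)nc2c1c(-c1ccco1)cn2[C@@H]1O[C@H](CO)[C@@H](O)[C@H]1O`) gives > 100000 nM, which is likewise a limit. Compound 2 therefore offers no exact starting value, and it stands with compound 1 at the limit of > 100000 nM in this assay, at which 2 of the 2 values shown sit, on the scale. Compound 3 (`COc1nc(N)nc2c1c(-c1ccccc1)cn2[C@@H]1O[C@H](CO)[C@@H](O)[C@H]1O`) differs from compound 2 in one place (phenyl in place of furan-2-yl on an aromatic carbon), with phenyl in place of furan-2-yl on an aromatic carbon. Within the data shown here, no measured pair shows what this swap does. With only the limit of > 100000 nM in this assay, at which 2 of the 2 values shown sit, as a guide, no step beyond the scatter is expected in this assay. The estimated change is a number no higher from compound 2 to compound 3 (the limit leaves the size open) and would leave the result at the limit. Compound 3 is expected to give about 100000 nM (estimated range 30000 nM to 100000 nM) in this measurement.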

Compound 3, half-maximal inhibitory concentration: > 100000 nM
Compound 3: no number, only a limit (the forecaster's own chance of this, stated with the estimate: 80%); the middle value sits exactly at the limit.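

Compound 2 and compound 3 both give only a limit and not a number, so no step can be read for phenyl in place of furan-2-yl. The compounds shown leave open how far beyond that limit each one lies, and whether this swap changes the result at all.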